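Methoxy for methylamino on the purine-like core of compound 3

A few compounds are considered here, and "the series" means these few. Any claim that something is new, unique, unknown or untested is made for them only; others in the source may bear on it.

Compound 3 `CNc1ncnc2c1c(I)cn2[C@@H]1O[C@H](CO)[C@@H](O)[C@H]1O` reaches only the limit of a functional assay on CCRF-CEM cells (Homo sapiens), read by MTT assay, with a stated time of 72 h (a higher number here means a weaker inhibitor, a lower number a stronger inhibitor), at > 100000 nM; that limit is all that is known of it. Its two companions give numbers. Compound 1 `Cc1ncnc2c1c(I)cn2[C@@H]1O[C@H](CO)[C@@H](O)[C@H]1O`, carrying methyl at the same place, gives 5480 nM in this assay, and compound 2 `COc1ncnc2c1c(-c1ccoc1)cn2[C@@H]1O[C@H](CO)[C@@H](O)[C@H]1O`, carrying methoxy beside a different group on the five-membered ring, gives 110 nM. Going by the values given here, the one measured step among them, an at least 18-fold higher number from compound 1 to compound 3 (1.26 log units; beyond the scatter), shows that methylamino at this carbon costs much; it is the only step that bears on the change ahead, since compound 2 differs from compound 4 in two places and offers no step of its own.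

Compound 4 `COc1ncnc2c1c(I)cn2[C@@H]1O[C@H](CO)[C@@H](O)[C@H]1O` differs from compound 3 as follows: methoxy in place of methylamino on an aromatic carbon. With methyl far stronger than methylamino and methoxy shown potent in compound 2, a fall in number back toward compound 1 is expected, and an at least 33-fold lower number from compound 3 to compound 4 (1.52 log units; beyond the scatter) is the expected size of it. For compound 4 an estimate of 3000 nM in this assay is expected, with a range from 500 nM to 30000 nM.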

Compound 4, half-maximal inhibitory concentration: 1150 nM
For compound 4 the middle estimate is 2.6-fold (0.42 log units) above the measured one; the range from low to high includes it.
By their numbers in this assay, from the lowest: compound 2; then compound 4; then compound 1. At a limit, above all of these: compound 3.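

Compound 3 stands only at a limit, so the step of methoxy in place of methylamino on this aromatic carbon, an at least 86-fold lower number from compound 3 to compound 4 (1.93 log units; beyond the scatter), is a bound and not a measured size: the limit of > 100000 nM in this assay, at which 1 of the 4 values shown sits. With iodo held, methoxy in place of methyl gives a 4.8-fold lower number from compound 1 to compound 4 (0.68 log units; beyond the scatter) in this assay, which shows that this carbon tolerates methoxy better than either of the other two groups shown. With methoxy held, iodo in place of furan-3-yl gives a 10-fold higher number from compound 2 to compound 4 (1.02 log units; beyond the scatter), so the group on the five-membered ring also moves the number by a large step.

On these data alone, what an unsubstituted amine or a longer chain such as ethoxy would do at this carbon remains open. So does whether furan-3-yl would bring the same change with methyl at this carbon.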